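The source may report more compounds than this note shows. Statements on the series, on what has been measured and on what is new or still open speak of the compounds shown alone.

Measured compounds:
compound 1, `COc1cccc(CNC(=O)c2nc(Br)c3cccnc3c2N[C@H]2CC[C@H](N)CC2)c1`, "not determined" (no result reported) in a functional assay on MCF7 cells (Homo sapiens) for cytotoxicity, read by MTT assay, with a stated time of 72 h; on this read-out lower numbers stand for stronger inhibition and higher numbers for weaker inhibition
compound 2, `N[C@H]1CC[C@H](Nc2c(C(=O)NCc3ccccn3)nc(Br)c3cccnc23)CC1`, 15000 nM
compound 3, `CN(C)c1ccc(CNC(=O)c2nc(Br)c3cccnc3c2N[C@H]2CC[C@H](N)CC2)cc1`, 5000 nM

Compound 1 has no number in this assay. Compound 3 holds the lowest of the two numbers, compound 2 being its nearest neighbour through the step of a 3.0-fold lower number from compound 2 to compound 3 (0.48 log units; beyond the scatter), which is beyond the scatter.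

Compound 4, `N[C@H]1CC[C@H](Nc2c(C(=O)NC3CCCCC3)nc(Br)c3cccnc23)CC1`, differs from compound 3 as follows: cyclohexyl in place of 4-(dimethylamino)benzyl on an amide-type nitrogen. Within the data shown here, the only step that touches the group on the amide-type nitrogen is a 3.0-fold lower number from compound 2 to compound 3 (0.48 log units; beyond the scatter), a modest change, and no measured compound carries a cyclohexyl there. Compound 4 is therefore expected to lie near compound 3, with a small step of a 1.6-fold higher number from compound 3 to compound 4 (0.20 log units; within the scatter) that may sit within the scatter. The estimate for compound 4 in this assay is 8000 nM, in the range 2500 nM to 25000 nM.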

Compound 4, half-maximal inhibitory concentration: 5200 nM
Compound 4: the middle estimate sits 1.5-fold (0.19 log units) above what was measured; the measured number falls inside the stated range.
By their numbers in this assay, from the lowest: compounds 3 and 4 (each within the scatter of the next); then compound 2.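

In this assay, the group on the amide-type nitrogen need not hold an aromatic ring: cyclohexyl, a non-aromatic ring of carbon only, stands level with 4-(dimethylamino)benzyl (a 1.0-fold higher number from compound 3 to compound 4 (0.02 log units; within the scatter)). Cyclohexyl in place of (pyridin-2-yl)methyl gives a modest step beyond the scatter (a 2.9-fold lower number from compound 2 to compound 4 (0.46 log units; beyond the scatter)). Nothing at hand explains these numbers. The compounds shown leave open how a smaller ring such as cyclopentyl would read at this nitrogen. They also leave open whether an amine or a carboxylic acid on the cyclohexyl would shift the number.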